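This account rests on a few compounds, and the source may have more. Where it says the series, first, only, none or still open, it means among the compounds named here.

Measured compounds:
Compound 1, `OCC(F)(F)C(F)(F)C(F)(F)C(F)F`, gives 1.89.
Compound 2, `CC(F)(F)COc1ccc2[nH]ccc2c1`, gives 2.7.
Compound 3, `CC(=O)N1CCC[C@H]1C(=O)OCCF`, gives -0.43.

All three numbers come from a physicochemical assay for lipophilicity, read by NMR; on this read-out higher numbers stand for higher lipophilicity and lower numbers for lower lipophilicity. Among them compound 2 has the highest reading; compound 1 comes nearest, with a number beyond the scatter below it, and compound 3 lies furthest away, also beyond the scatter. The unmeasured compound 4, `FCC(F)COc1ccc2[nH]ccc2c1`, is compound 2 with its atoms joined differently: 1,2-difluoroethyl in place of 1,1-difluoroethyl on a saturated chain carbon bound to an oxygen on an aromatic ring. Going by the values given here, no measured pair shows this kind of change, so no step size is known for it. The step expected from compound 2 to compound 4 in this assay is a number 0.30 log units lower from compound 2 to compound 4 (within the scatter), a small downward shift at about the edge of the scatter. Compound 4 is therefore expected to give 2.4, within a range from 2 to 2.8.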

Compound 4, partition coefficient: 2.3
Compound 4: middle estimate off by 0.10 log units, on the high side, within the range that was stated.
By their numbers in this assay, from the lowest: compound 3; then compound 1; then compound 4; then compound 2.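

At this position, on a saturated chain carbon bound to an oxygen on an aromatic ring, 1,2-difluoroethyl in place of 1,1-difluoroethyl gives in this assay a number 0.40 log units lower from compound 2 to compound 4 (beyond the scatter). The two compounds hold the same atoms, so joining them differently is enough to shift this reading beyond the scatter, which the unrelated earlier compounds could not show. Nothing on hand accounts for the shift. Going by these compounds, whether trifluoroethyl or a longer fluorinated chain at this place would follow compound 4, and whether the step holds with an amine on the shared core, stays open.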